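Swapping the amine chain for an ether at the sulfonamide aryl

The source may hold more compounds than are shown below. What is called first, only, known or untested is meant among the compounds shown, and "the series" means these compounds.

Three compounds share a core and were tested in a functional assay on RS4-11 cells (Homo sapiens) for inhibition, read by CCK-8 assay, with a stated time of 72 h; on this read-out lower numbers stand for stronger inhibition and higher numbers for weaker inhibition. Compound 1 `COc1ccc(C2=C(CN3CCN(c4ccc(C(=O)NS(=O)(=O)c5ccc(NCC6CCOCC6)c([N+](=O)[O-])c5)c(Oc5cnc6[nH]ccc6c5)c4)CC3)CCC(C)(C)C2)cc1` gives 12 nM. Among the compounds with values here, compound 2 `CC1(C)CCC(CN2CCN(c3ccc(C(=O)NS(=O)(=O)c4ccc(NCC5CCOCC5)c([N+](=O)[O-])c4)c(Oc4cnc5[nH]ccc5c4)c3)CC2)=C(c2ccc(C(F)(F)F)c(Cl)c2)C1` gives 81 nM, and the one step between them, a 6.8-fold higher number from compound 1 to compound 2 (0.83 log units; beyond the scatter), concerns the aryl group on the double-bonded ring carbon. Compound 3 `CCN(CC)CCCNc1ccc(S(=O)(=O)NC(=O)c2ccc(N3CCN(CC4=C(c5ccc(C(F)(F)F)cc5)CC(C)(C)CC4)CC3)cc2Oc2cnc3[nH]ccc3c2)cc1[N+](=O)[O-]` gives 3 nM, the lowest of the three numbers, with compound 1 nearest and compound 2 furthest, both beyond the scatter.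

Compound 4 `CC(Oc1ccc(S(=O)(=O)NC(=O)c2ccc(N3CCN(CC4=C(c5ccc(C(F)(F)F)cc5)CC(C)(C)CC4)CC3)cc2Oc2cnc3[nH]ccc3c2)cc1[N+](=O)[O-])C1CCOCC1` differs from compound 3 at a different place: a group of 9 heavy atoms (7 carbon, 2 oxygen; one six-membered non-aromatic ring with 1 hetero atom) in place of a group of 9 heavy atoms (7 carbon, 2 nitrogen; no ring), on an aromatic carbon. Within the data shown here, no measured step touches this aromatic carbon, ortho to the nitro group and para to a large group, so the only step known, from compound 1 to compound 2, does not bear on it. With no guide, the author expects at most a modest rise, a 3.3-fold higher number from compound 3 to compound 4 (0.52 log units; beyond the scatter), for compound 4. Compound 4 is therefore estimated at 10 nM in this assay, within a range from 3 nM to 40 nM.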

Compound 4, half-maximal inhibitory concentration: 269 nM
The estimate for compound 4 lay 27-fold (1.43 log units) below the measured number; measured number above the stated range.
By their numbers in this assay, from the lowest: compound 3; then compound 1; then compound 2; then compound 4.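

Within the data shown here, this is the first measured change on the aromatic carbon ortho to a nitro group, and in this assay it brings a 90-fold higher number from compound 3 to compound 4 (1.95 log units; beyond the scatter) and counts as a large step. The two groups have the same count of heavy atoms and of hydrogen-bond acceptors, so these counts alone do not settle the read-out at this position. The change removes the hydrogen-bond donor and the diethylamino end of the chain and brings in a six-membered non-aromatic ring all at once, and nothing measured here explains the rise.

The compounds shown leave open which part of this exchange carries the step. A 3-(diethylamino)propoxy group, or a group joined through an amine nitrogen and ending in the same six-membered ring, would separate the linking atom from the end of the chain.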